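This account rests on a few compounds, and the source may have more. Where it says the series, first, only, none or still open, it means among the compounds named here.

Of the compounds shown here, two with a shared core have been measured in a functional assay on HepG2 cells (Homo sapiens) for antiproliferative activity, read by MTT assay, with a stated time of 48 h; a lower number here means a stronger inhibitor, a higher number a weaker inhibitor. Compound 1 `COc1ccc(N(C)c2ccnc(Cl)n2)cc1F` gives 844 nM, while compound 2 `COc1ccc(N(C)c2ccnc(Cl)n2)cc1OCCBr` gives 7720 nM, the higher number of the pair, which makes compound 2 the weaker inhibitor of the two. Among the measured compounds shown here, the one measured step, a 9.1-fold higher number from compound 1 to compound 2 (0.96 log units; beyond the scatter), lies beyond the scatter and came with 2-bromoethoxy in place of fluoro on an aromatic carbon.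

Compound 3 `COc1ccc(N(C)c2ccnc(Cl)n2)cc1OCCCCCBr` keeps the core of compound 2 and differs in its chain: 3-bromopropyl in place of bromo on a saturated chain carbon, two bonds along the chain from an oxygen on an aromatic ring. Cut further out, the same difference reads 2-bromoethoxy to (5-bromopentyl)oxy. For the measured compounds named here, only the step from compound 1 bears on this, and only loosely, since it exchanged fluoro for a bromine-bearing chain, whereas here a bromine-bearing chain simply grows. That step shows that a change in this substituent can shift the number in this assay, but it gives no direction for chain length. No step beyond the scatter is therefore expected, though a modest one in either direction remains possible. The expected step is a 1.2-fold lower number from compound 2 to compound 3 (0.07 log units; within the scatter). For compound 3 the estimated value is 6500 nM, with an expected range from 2200 nM to 19000 nM.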

Compound 3, half-maximal inhibitory concentration: > 10000 nM
Compound 3: only a limit was reported; the forecaster's own chance of this, stated with the estimate: 10%; middle value at least 1.5-fold (0.18 log units) away from the limit.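

In this assay compound 3 gives > 10000 nM, which is a limit and not a number. Lengthening 2-bromoethoxy to (5-bromopentyl)oxy gives an at least 1.2-fold higher number from compound 2 to compound 3 (0.11 log units; that floor lies within the scatter), so the longer chain brings no lower number, but this floor alone does not establish that it is weaker than the shorter chain, whereas the comparison with fluoro gives an at least 11-fold higher number from compound 1 to compound 3 (1.07 log units; beyond the scatter), placing this chain, like 2-bromoethoxy, clearly on the weaker side of fluoro at this position. Both steps can be read only as floors because the value for compound 3 is a limit: the limit of > 10000 nM in this assay, at which 1 of the 3 values shown sits.

How far the number for compound 3 lies from that of compound 2 remains open, and with only these chains shown, so does any trend with chain length, which a chain of intermediate length, such as 3-bromopropoxy, could help to test. Also open, on these data alone, is whether the terminal bromine matters in its own right, a question that a plain pentyloxy chain or one ending in an amine or a hydroxyl group would address.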